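The source may hold more compounds than are shown below. What is called first, only, known or untested is meant among the compounds shown, and "the series" means these compounds.

Compound 1 `CC1=C(CCC(=O)OCCCCOc2no[n+]([O-])c2S(=O)(=O)c2ccccc2)C(=O)c2c(O)cccc2C1=O` is tested in a functional assay on A549 cells (Homo sapiens) for inhibition, read by MTT assay, with a stated time of 72 h (on this read-out lower numbers stand for stronger inhibition and higher numbers for weaker inhibition), where compound 1 gives 8310 nM. Compound 2 `CC1=C(C(C)CC(=O)OCC(C)COc2no[n+]([O-])c2S(=O)(=O)c2ccccc2)C(=O)c2c(O)cccc2C1=O` gives 12800 nM in this assay. Compound 3 `CC1=C(CCC(=O)OCCCOc2no[n+]([O-])c2S(=O)(=O)c2ccccc2)C(=O)c2c(O)cccc2C1=O` reaches only a limit of the assay, > 20000 nM, not a true number. Among the compounds with values here, compound 3 thus stands at the limit of > 20000 nM in this assay, at which 1 of the 3 values shown sits, with no measured step to any other compound. The unmeasured compound 4 `CC1=C(CCC(=O)OCC(C)COc2no[n+]([O-])c2S(=O)(=O)c2ccccc2)C(=O)c2c(O)cccc2C1=O` differs from compound 3 by methyl in place of hydrogen on a saturated chain carbon bound to two saturated chain carbons. Within the data shown here, compound 2 carries the same branched linker and gives 12800 nM in this assay, yet compound 2 also differs from compound 3 in a second place, so no single measured step guides the expectation. The step from compound 3 to compound 4 is expected to be an at least 1.3-fold lower number from compound 3 to compound 4 (0.12 log units; that floor lies within the scatter). Compound 4 is estimated at about 15000 nM in this assay, most likely between 6000 nM and 40000 nM.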

Compound 4, half-maximal inhibitory concentration: 18200 nM
The estimate for compound 4 lay 1.2-fold (0.08 log units) below the measured number; the measured number falls inside the stated range.
By their numbers in this assay, from the lowest: compounds 1, 2 and 4 (each within the scatter of the next, the first and the last beyond it). At a limit, above all of these: compound 3.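

Compound 3 stands at a limit of the assay, not at a true number: the limit of > 20000 nM in this assay, at which 1 of the 4 values shown sits. Methyl in place of hydrogen on this saturated chain carbon gives an at least 1.0-fold lower number from compound 3 to compound 4 (0.04 log units; that floor lies within the scatter), so this step has only a floor, and its true size stays unknown. Hydrogen in place of methyl on a saturated chain carbon bound to a double-bonded ring carbon and a saturated chain carbon gives a 1.4-fold higher number from compound 2 to compound 4 (0.15 log units; within the scatter), so this second change also stays within the scatter. Going by these compounds, whether ethyl or hydroxyl on the linker's branching carbon would move the number beyond the scatter remains open.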